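Replacing nitro with (methylsulfonyl)oxy in compound 3

A few compounds are considered here, and "the series" means these few. Any claim that something is new, unique, unknown or untested is made for them only; others in the source may bear on it.

Values from a functional assay on the whole organism with Canis familiaris (Canis lupus familiaris) as the target (a higher number here means that more compound is needed for the effect, a lower number that less compound is needed), so far

compound 1 `COc1ccc(-c2nc3cc[nH]cc-3n2)c(OC)c1` gives 0.3 mg/kg
compound 2 `COc1cc(Cl)ccc1-c1nc2cc[nH]cc-2n1` gives 0.23 mg/kg
compound 3 `COc1cc([N+](=O)[O-])ccc1-c1nc2cc[nH]cc-2n1` gives 0.015 mg/kg
compound 4 `COc1cc(OS(C)(=O)=O)ccc1-c1nc2cc[nH]cc-2n1` is not yet measured

Compound 3 holds the lowest number of the three (0.015 mg/kg), and its gaps to both others lie beyond the scatter. The change to compound 4 is (methylsulfonyl)oxy in place of nitro on an aromatic carbon.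

The measured steps that bear on this are the two that bring in nitro. These are a 20-fold lower number from compound 1 to compound 3 (1.30 log units; beyond the scatter) and a 15-fold lower number from compound 2 to compound 3 (1.19 log units; beyond the scatter) and each is large. Chloro in place of methoxy gave only a 1.3-fold lower number from compound 1 to compound 2 (0.12 log units; within the scatter) and stays within the scatter. Within the data shown here, no measured compound carries (methylsulfonyl)oxy, so the data do not show whether it can match nitro.

The low number of compound 3 has been seen with nitro alone, so part of that gain is expected to be lost. The number in this assay should therefore go up, but it is not expected to reach the level of compound 2 (0.23 mg/kg). The estimated step is a 4.0-fold higher number from compound 3 to compound 4 (0.60 log units; beyond the scatter) and it is expected to point upward. For compound 4 the estimate is 0.06 mg/kg with an expected range of 0.015 mg/kg to 0.2 mg/kg for the measurement.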

Compound 4, dose for half-maximal effect: 0.006 mg/kg
The estimate for compound 4 lay 10-fold (1.00 log units) above the measured number, outside the stated range (below it).
By their numbers in this assay, from the lowest: compound 4; then compound 3; then compounds 2 and 1 (each within the scatter of the next).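

In this assay, the position meta to a methoxy group is not limited to nitro for reaching a low number: (methylsulfonyl)oxy in place of nitro gives a 2.5-fold lower number from compound 3 to compound 4 (0.40 log units; beyond the scatter) and so goes further, though only modestly. Against the other two groups at this position, the same group gives a 38-fold lower number from compound 2 to compound 4 (1.58 log units; beyond the scatter) and a 50-fold lower number from compound 1 to compound 4 (1.70 log units; beyond the scatter), both large steps, so nitro and (methylsulfonyl)oxy stand well apart from chloro and methoxy in this short set. Nothing shown on these compounds accounts for the difference between the two pairs of groups, so no cause can be given for this change.

Going by these compounds, it remains open which part of (methylsulfonyl)oxy carries the low number, and a methylsulfonyl group bound directly to the ring, a sulfonamide or a longer chain on the sulfonyl group would separate the linking oxygen from the rest. A nitrile or a carboxylic acid at the same position would show whether the low numbers extend beyond these two groups, and a shift of (methylsulfonyl)oxy to another ring carbon would show how much depends on the position itself.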